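This account rests on a few compounds, and the source may have more. Where it says the series, first, only, none or still open, it means among the compounds named here.

In an ADME assay on liver (Homo sapiens) for metabolic stability, using microsomes (a lower number here means that the compound disappears faster, a higher number that the compound lasts longer), compound 1 (`CC[C@@H]1C[C@]1(NC(=O)[C@@H]1C[C@@H](Oc2ncc(OC)c3ccc(Cl)cc23)CN1C(=O)[C@@H](NC(=O)OC(C)(C)C)C(C)(C)C)C(=O)NS(=O)(=O)C1CC1`) gives 0.567 h and compound 2 (`COc1cnc(O[C@@H]2C[C@@H](C(=O)N[C@]3(C(=O)NS(=O)(=O)C4CC4)C[C@H]3C3CC3)N(C(=O)[C@@H](NC(=O)OC3(C)CCCC3)C(C)(C)C)C2)c2cc(Cl)ccc12`) gives 0.4 h as half-life. These two values lie within the scatter of each other, and that is all the numbers allow to be said of where compound 2 stands. The next compound, compound 3 (`COc1cnc(O[C@@H]2C[C@@H](C(=O)N[C@]3(C(=O)NS(=O)(=O)C4CC4)C[C@H]3C3CC3)N(C(=O)[C@@H](NC(=O)O[C@H](C)C(F)(F)F)C(C)(C)C)C2)c2cc(Cl)ccc12`), carries 1-(trifluoromethyl)ethyl in place of 1-methylcyclopentyl on an oxygen next to a carbonyl group. Among the compounds with values here, the two measured compounds differ in more than one place, and no measured pair shows this change alone, so the size of the step rests on judgement. A modest rise in this assay is expected, possibly not clear of the scatter. The expected 1.8-fold higher number from compound 2 to compound 3 (0.24 log units; within the scatter) is small and upward. For compound 3 the estimated half-life is 0.7 h with an expected range from 0.3 h to 1.5 h for repeated measurements.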

Compound 3, half-life: 2.12 h
Estimate against measurement, compound 3: 3.0-fold (0.48 log units) below; measured number outside the range, above it.
By their numbers in this assay, from the lowest: compounds 2 and 1 (each within the scatter of the next); then compound 3.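

Working notes: on an oxygen next to a carbonyl group, 1-(trifluoromethyl)ethyl in place of 1-methylcyclopentyl gives a 5.3-fold higher number from compound 2 to compound 3 (0.72 log units; beyond the scatter) in this assay. This is the only single-place change shown, and it establishes that this position alone can move the half-life beyond the scatter, with the rest of the structure held constant. No measurement shown here accounts for the step.

The step combines the loss of a five-membered carbon ring with the entry of fluorine and a defined stereocentre, so an isopropyl group on the same oxygen would be needed to separate these parts. Also open, on these data alone, are the opposite stereocentre of the 1-(trifluoromethyl)ethyl group and whether the step carries over to the core of compound 1.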